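Aryl variation on the quinolinone core against the GnRH receptor

A few compounds are considered here, and "the series" means these few. Any claim that something is new, unique, unknown or untested is made for them only; others in the source may bear on it.

Measured so far:
compound 1 `O=[N+]([O-])c1cc2c(OCCC3CCCCN3)c(-c3cccc(Cl)c3)c(O)nc2cc1Cl`, 40 nM
compound 2 `CC(=O)OCc1cc(C)cc(-c2c(O)nc3cc(Cl)c([N+](=O)[O-])cc3c2OCCC2CCCCN2)c1`, 45 nM

In a functional assay on cells (Pituitary gland cell) for antagonist activity at Gonadotropin-releasing hormone receptor (Rattus norvegicus) (on this read-out lower numbers stand for stronger inhibition and higher numbers for weaker inhibition), compound 2 gives the higher of the two numbers, yet the gap between the two is small: a 1.1-fold higher number from compound 1 to compound 2 (0.05 log units; within the scatter). Compound 3 `O=[N+]([O-])c1cc2c(OCCC3CCCCN3)c(-c3ccc4ccccc4c3)c(O)nc2cc1Cl` is the next step: naphthalen-2-yl in place of 3-(acetoxymethyl)-5-methylphenyl on an aromatic carbon. Among the compounds with values here, only one measured step bears on this, the aryl exchange from compound 1 to compound 2, and it stayed within the scatter. A second aryl exchange at the same carbon is therefore expected to give no step beyond the scatter, a 1.1-fold lower number from compound 2 to compound 3 (0.05 log units; within the scatter). For compound 3 in this assay the expected value is 40 nM, ranging from 15 nM to 120 nM.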

Compound 3, half-maximal inhibitory concentration: 53 nM
The estimate for compound 3 lay 1.3-fold (0.12 log units) below the measured number; the range from low to high includes it.
By their numbers in this assay, from the lowest: compounds 1, 2 and 3 (each within the scatter of the next).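

In this assay, the exchange at this aromatic carbon now covers a fused aryl group: naphthalen-2-yl gives a 1.2-fold higher number from compound 2 to compound 3 (0.07 log units; within the scatter) and a 1.3-fold higher number from compound 1 to compound 3 (0.12 log units; within the scatter). A second aromatic ring can thus enter, and the hydrogen-bond acceptors of 3-(acetoxymethyl)-5-methylphenyl can leave, without a step beyond the scatter. No supporting data bear on why these aryl groups read alike. Open, as far as these compounds go, is whether an aryl group carrying an amine or a carboxylic acid, or a plain methyl in place of the aryl group, would give a step beyond the scatter.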